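The source may hold more compounds than are shown below. What is called first, only, known or untested is meant among the compounds shown, and "the series" means these compounds.

In a functional assay on MGC-803 cells (Homo sapiens) for cytotoxicity, read by MTT assay, with a stated time of 48 h (a lower number here means a stronger inhibitor, a higher number a weaker inhibitor), compound 1 `CC1=NN(C(=O)/C=C/c2ccccc2)C(c2ccccc2O)C1` gives 39600 nM as the only numeric result so far. Compound 2 `CC1=NN(C(=O)COc2ccc(Cl)cc2)C(c2ccccc2O)C1`, which carries a different side chain on the shared core, is reported as "not active" (no number reported) and so stands without a number, leaving no measured baseline for the next step. Compound 3 `CC1=NN(C(=O)COc2ccc(Cl)cc2)C(c2cc(Br)ccc2O)C1` keeps that side chain and differs through bromo in place of hydrogen on an aromatic carbon in one place, so that 2-hydroxyphenyl becomes 5-bromo-2-hydroxyphenyl. Going by the values given here, no measured pair shows what this change does, so the size of the step cannot be read from the data. A modest move towards stronger inhibition is expected, at best into the weak range set by compound 1 at 39600 nM in this assay and a second result without a number remains quite possible. For compound 3 the estimated value is 40000 nM with an expected range from 12000 nM to 100000 nM in this read-out.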

Compound 3, half-maximal inhibitory concentration: 23600 nM
Compound 3: the middle estimate sits 1.7-fold (0.23 log units) above what was measured; measured number inside the range.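

No step can be read from compound 2 to compound 3: in this assay compound 3 gives 23600 nM while compound 2 has no number. On these data alone, what bromo in place of hydrogen does to inhibition stays open. No supporting evidence bears on this result.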